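The source may hold more compounds than are shown below. What is called first, only, known or untested is meant among the compounds shown, and "the series" means these compounds.

Measured so far:
- compound 1 `CC(C)n1nc(-c2ccccc2)c(-c2ccccc2)cc1=O`: 152000 nM
- compound 2 `CCCCCCNc1cc(-c2ccccc2)c(-c2ccccc2)nn1`: 24000 nM

Both compounds were tested in an assay on microsomes from liver for inhibition of sterol O-acyltransferase 1 (Rattus norvegicus); on this read-out lower numbers stand for stronger inhibition and higher numbers for weaker inhibition. Compound 1 `CC(C)n1nc(-c2ccccc2)c(-c2ccccc2)cc1=O` gives 152000 nM in this assay. Compound 2 `CCCCCCNc1cc(-c2ccccc2)c(-c2ccccc2)nn1` gives 24000 nM in this assay, the lower of the two numbers, and the gap between compound 2 and compound 1 is beyond the scatter, so compound 2 counts as the stronger inhibitor of the pair.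

The next compound, compound 3 `CCCCCCCOc1cc(-c2ccccc2)c(-c2ccccc2)nn1`, keeps the shared core of compound 2 and changes one group: heptyloxy in place of hexylamino on an aromatic carbon. Within the data shown here, no measured pair with a change of this kind is available, so the size of the step rests on the structural change alone. The chain stays roughly as long and only the linking atom and its hydrogen differ; the expected step of a 1.3-fold higher number from compound 2 to compound 3 (0.10 log units; within the scatter) is therefore small, within the scatter or slightly toward a higher number. Compound 3 is estimated at 30000 nM, with a range from 8000 nM to 120000 nM.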

Compound 3, half-maximal inhibitory concentration: 58000 nM
Beside the measured number, compound 3's estimate is 1.9-fold (0.29 log units) below it; low and high end bracket the measured number.
By their numbers in this assay, from the lowest: compound 2; then compound 3; then compound 1.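

Replacing hexylamino with heptyloxy on this aromatic carbon, next to the ring nitrogen, gives a 2.4-fold higher number from compound 2 to compound 3 (0.38 log units; beyond the scatter) in this assay, so the choice of group at this position has a modest but real effect on the read-out. The swap changes more than one feature: the group that leaves has 1 hydrogen-bond donor and 7 heavy atoms, while the group that enters has 0 hydrogen-bond donors and 8 heavy atoms, and this single step cannot separate those differences. Nothing measured here explains the weaker inhibition.

Whether the linking atom, the donor hydrogen or the extra chain carbon accounts for the step remains open, and a heptylamino or hexyloxy group at this position would help separate them. From the compounds shown here alone, it also remains open whether a longer chain or a carboxylic acid here would give a lower number.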